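Swapping 5-chlorothiophen-2-yl for phenyl on the shared core

This account rests on a few compounds, and the source may have more. Where it says the series, first, only, none or still open, it means among the compounds named here.

In a functional assay on MCF7 cells (Homo sapiens) for cytotoxicity, read by MTT assay, with a stated time of 96 h (a lower number here means a stronger inhibitor, a higher number a weaker inhibitor), compound 1 `Cc1cc2c(c(=O)o1)C(c1ccc(Br)cc1)C(C#N)=C(N)O2` gives 35000 nM, compound 2 `Cc1ccc(C2C(C#N)=C(N)Oc3cc(C)oc(=O)c32)cc1` gives 54000 nM and compound 3 `Cc1cc2c(c(=O)o1)C(c1ccc(Cl)s1)C(C#N)=C(N)O2` gives 12000 nM. Compound 3 has the lowest of these three numbers, which makes it the strongest inhibitor so far.

Compound 4 `Cc1cc2c(c(=O)o1)C(c1ccccc1)C(C#N)=C(N)O2` has not yet been measured. It differs from compound 3 in one place: phenyl in place of 5-chlorothiophen-2-yl on a saturated ring carbon. In words, phenyl takes the place of 5-chlorothiophen-2-yl on a saturated ring carbon.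

Two measured steps change the group at this same place. One is a 2.9-fold lower number from compound 1 to compound 3 (0.46 log units; beyond the scatter), and the other is a 4.5-fold lower number from compound 2 to compound 3 (0.65 log units; beyond the scatter). Both are modest and both run towards the thiophene compound, so the swap to phenyl points the opposite way. Neither compound 1 nor compound 2 carries a bare phenyl, since each has a substituent on its aromatic ring. Even so, exchanging those substituents gave a 1.5-fold higher number from compound 1 to compound 2 (0.19 log units; within the scatter), so the choice between them shows no clear effect. Within the data shown here, a bare phenyl is therefore expected to land near compounds 1 and 2, though no measured compound tests this directly. The expected change is a 3.5-fold higher number from compound 3 to compound 4 (0.54 log units; beyond the scatter), a modest step towards a weaker inhibitor. Compound 4 is estimated at 42000 nM, with an expected range from 18000 nM to 95000 nM.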

Compound 4, half-maximal inhibitory concentration: 46000 nM
The estimate for compound 4 lay 1.1-fold (0.04 log units) below the measured number; measured number inside the range.
By their numbers in this assay, from the lowest: compound 3; then compounds 1, 4 and 2 (each within the scatter of the next).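

In this assay, the bare phenyl of compound 4 supplies the reference that compounds 1 and 2 lacked: a 1.3-fold higher number from compound 1 to compound 4 (0.12 log units; within the scatter) and a 1.2-fold lower number from compound 2 to compound 4 (0.07 log units; within the scatter) both lie within the scatter, so bromo, methyl and hydrogen on this aromatic ring cannot be told apart here. The direct swap, a 3.8-fold higher number from compound 3 to compound 4 (0.58 log units; beyond the scatter), is a modest step beyond the scatter, and it shows that the lower number of compound 3 holds against an unsubstituted phenyl as well as against the two substituted ones. At this saturated ring carbon, then, the measured difference follows the exchange of the whole 5-chlorothiophen-2-yl group for a phenyl ring, while the small substituents tried on that phenyl ring show no clear effect, and nothing measured here explains the difference.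

As far as these compounds go, whether the lower number belongs to the five-membered sulfur ring or to its chlorine stays open, as the 5-chlorothiophen-2-yl group brings both at once. Also open, from the compounds shown here alone, is how a plain thiophen-2-yl, a pyridine ring, or a phenyl ring carrying an amine or a carboxylic acid would behave at this place.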